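Swapping methoxy for pyrrolidinyl on a furan-linked pyrrolidine series

The source may report more compounds than this note shows. Statements on the series, on what has been measured and on what is new or still open speak of the compounds shown alone.

Of the compounds shown here, two built on the same core have been measured in an ADME assay on microsomes from liver (Homo sapiens) for metabolic stability, read by LC-MS, using NADPH, with a stated time of 60 min, tested at 1 uM; a lower number here means that the compound disappears faster, a higher number that the compound lasts longer. Compound 1, `CN(C)c1cccc(C2CCCN2Cc2ccc(-c3ccccc3[N+](=O)[O-])o2)c1`, gives 0.0095 h. Compound 2, `COc1ccc(C2CCCN2Cc2ccc(-c3ccccc3[N+](=O)[O-])o2)cc1`, gives 0.0183 h. Going by the values given here, the two numbers lie within the usual scatter of each other, so compound 2 cannot be told apart from compound 1 on this evidence; the only measured step, a 1.9-fold higher number from compound 1 to compound 2 (0.28 log units; within the scatter), is itself within the scatter.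

Compound 3, `O=[N+]([O-])c1ccccc1-c1ccc(CN2CCCC2c2ccc(N3CCCC3)cc2)o1`, is not yet measured. It differs from compound 2 in one place: pyrrolidin-1-yl in place of methoxy on an aromatic carbon. The step from compound 1 to compound 2 is the only one that bears on this change, as it also swaps the group on the aromatic ring carried by the saturated ring, and that step was small. No step beyond the scatter is therefore expected in this assay, in either direction.

Compound 3 is expected to give about 0.012 h, within a range from 0.005 h to 0.03 h. This estimate corresponds to an expected step of a 1.5-fold lower number from compound 2 to compound 3 (0.18 log units; within the scatter).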

Compound 3, half-life: 0.169 h
Compound 3: the middle estimate sits 14-fold (1.15 log units) below what was measured; measured number above the stated range.
By their numbers in this assay, from the lowest: compounds 1 and 2 (each within the scatter of the next); then compound 3.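

Going by these compounds alone, at this position, on an aromatic carbon of a six-membered aromatic ring of carbon only and para to a large group, the choice of substituent clearly matters in this assay: pyrrolidin-1-yl in place of methoxy gives a 9.2-fold higher number from compound 2 to compound 3 (0.97 log units; beyond the scatter) and is the first step in this set to lie beyond the scatter. The earlier step between compound 1 and compound 2 stayed within the scatter, so it gave no sign that a change on this ring could shift the half-life so clearly. Nothing measured in this set accounts for the longer half-life of compound 3.

On these data alone, what remains open is which feature of the entering group goes with the change: its ring, its nitrogen on the aromatic carbon, or simply its greater number of heavy atoms. Groups such as piperidin-1-yl, morpholin-4-yl or an open-chain diethylamino at this same place would help to separate these possibilities, and the single pair of compound 2 and compound 3 cannot show whether the same swap would behave alike on another core.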